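Lipophilicity notes on the sulfamate series: aniline substituent swap

A few compounds are considered here, and "the series" means these few. Any claim that something is new, unique, unknown or untested is made for them only; others in the source may bear on it.

Measured so far in a physicochemical assay for lipophilicity; on this read-out lower numbers stand for lower lipophilicity and higher numbers for higher lipophilicity:
compound 1 `CCN(Cc1cccc(Br)c1)c1ccc(C(=O)N2CCc3ccc(OS(N)(=O)=O)cc3C2)cc1` gives 1.93
compound 2 `CCN(Cc1ccccn1)c1ccc(C(=O)N2CCc3ccc(OS(N)(=O)=O)cc3C2)cc1` gives 1.93
compound 3 `CN(C)CCCN(Cc1ccccc1)c1ccc(C(=O)N2CCc3ccc(OS(N)(=O)=O)cc3C2)cc1` gives 1.93

Compound 2 stands level with compounds 1 and 3 at the digits shown; its nearest neighbour is compound 1 and its furthest is compound 3, and both gaps lie within the scatter. Going by the values given here, the one single-point step among the measured compounds, no change at the digits printed from compound 1 to compound 2 (within the scatter), shows no change beyond the scatter. Compounds 2 and 3 differ in more than one place, so only their two values can be compared, and they too are level.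

Compound 4 `CCCN(Cc1ccccc1)c1ccc(C(=O)N2CCc3ccc(OS(N)(=O)=O)cc3C2)cc1` is not yet measured. It differs from compound 2 as follows: benzyl(propyl)amino in place of ethyl((pyridin-2-yl)methyl)amino on an aromatic carbon. The step that bears on this, no change at the digits printed from compound 1 to compound 2 (within the scatter), is an exchange of one aromatic ring on the same chain carbon and produced no movement. Among the compounds with values here, the change to compound 4 also alters the chain and removes the ring hetero atom, for which no measured step exists. The expected step of a number 0.22 log units higher from compound 2 to compound 4 (within the scatter) is therefore estimated as small, at most a slight rise. For compound 4 the value in this assay is estimated at 2.15, with a range from 1.6 to 2.7.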

Compound 4, partition coefficient: 1.93
Estimate against measurement, compound 4: 0.22 log units above; measured number inside the range.
By their numbers in this assay, from the lowest: compounds 1, 2, 3 and 4 (each within the scatter of the next).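

In this assay the exchange of ethyl((pyridin-2-yl)methyl)amino for benzyl(propyl)amino on an aromatic carbon, para to a large group, reads no change at the digits printed from compound 2 to compound 4 (within the scatter) and so extends the earlier ring swap to a change that also alters the chain and leaves a ring of carbon only. Hydrogen in place of dimethylamino on the chain reads no change at the digits printed from compound 3 to compound 4 (within the scatter) and benzyl(propyl)amino in place of (3-bromobenzyl)(ethyl)amino reads no change at the digits printed from compound 1 to compound 4 (within the scatter) in the same assay, so neither the dimethylamino group nor the bromine separates these compounds on this read-out. Nothing at hand offers an explanation for these level values.

Going by these compounds, whether a carboxylic acid on this substituent would also stay level remains open. So does the outcome for a hexyl chain in place of propyl.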